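The source may report more compounds than this note shows. Statements on the series, on what has been measured and on what is new or still open speak of the compounds shown alone.

Within the data shown here, compound 1 `COC(=O)N[C@H](C(=O)N1CCC[C@H]1C(=O)Nc1ccc([C@@H]2CC[C@@H](c3ccc(NC(=O)[C@@H]4CCCN4C(=O)[C@@H](NC(=O)OC)C(C)C)cc3)N2c2ccc([Si](C)(C)C)cc2)cc1)C(C)C` gives 288 nM in an ADME assay on the whole organism for pharmacokinetics, with Mus musculus as the target, read by HPLC, at a dose of 10 mg/kg by the oral route (a lower number here means less compound in the circulation, a higher number more compound in the circulation at the dose given), the higher of the two numbers so far. Compound 2 `CC[Si](CC)(CC)c1ccc(N2[C@H](c3ccc(NC(=O)[C@@H]4CCCN4C(=O)[C@@H](NC(=O)OC)C(C)C)cc3)CC[C@H]2c2ccc(NC(=O)[C@@H]3CCCN3C(=O)[C@@H](NC(=O)OC)C(C)C)cc2)cc1` gives 208 nM in this assay, and the step of a 1.4-fold lower number from compound 1 to compound 2 (0.14 log units; within the scatter) follows the enlargement of the silicon substituent on the aromatic carbon. Compound 3 `COC(=O)N[C@H](C(=O)N1CCC[C@H]1C(=O)Nc1ccc([C@@H]2CC[C@@H](c3ccc(NC(=O)[C@@H]4CCCN4C(=O)[C@@H](NC(=O)OC)C(C)C)cc3)N2c2ccc([Si](C)(C)C(C)(C)C)cc2)cc1)C(C)C` differs from compound 1 by tert-butyl in place of methyl on a silicon. Among the measured compounds shown here, the one measured step that bears on this, a larger group on the same silicon, stayed within the scatter, so a step of a 1.3-fold lower number from compound 1 to compound 3 (0.10 log units; within the scatter) is expected, not beyond the scatter. Compound 3 is therefore estimated at 230 nM, with a range of 100 nM to 550 nM.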

Compound 3, maximal plasma concentration: 222 nM
Beside the measured number, compound 3's estimate is 1.0-fold (0.02 log units) above it; low and high end bracket the measured number.
By their numbers in this assay, from the lowest: compounds 2, 3 and 1 (each within the scatter of the next).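

In this assay, tert-butyl in place of methyl on a silicon stays within the scatter (a 1.3-fold lower number from compound 1 to compound 3 (0.11 log units; within the scatter)), so this second enlargement at the silicon also leaves the maximal plasma concentration unresolved from that of compound 1. Two different silicon groups of equal heavy-atom count also stay within the scatter (a 1.1-fold higher number from compound 2 to compound 3 (0.03 log units; within the scatter)). No available measurement explains these numbers.

Left open is whether an amine or a carboxylic acid on the aromatic carbon, in place of the silicon group, would give a step beyond the scatter. The same question stands for a hydroxyethyl chain on the silicon.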